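Replacing 4-acetamidophenyl with (4-nitrophenyl)amino on a carbonyl carbon

A few compounds are considered here, and "the series" means these few. Any claim that something is new, unique, unknown or untested is made for them only; others in the source may bear on it.

In a functional assay on NCI-H460 cells (Homo sapiens) for positive allosteric modulation, read by MTT assay, with stated times of 2 h and 72 h, tested at 1 uM (a higher number here means a weaker inhibitor, a lower number a stronger inhibitor), compound 1 (`COc1cccc(-n2nnc(-c3ccccc3NC(=O)c3ccc(N)cc3)n2)c1`) gives 217 nM, and compound 2 (`COc1cccc(-n2nnc(-c3ccccc3NC(=O)c3ccc(NC(C)=O)cc3)n2)c1`) gives 725 nM. Compound 2 therefore stands as the weaker inhibitor of the two measured compounds. Among the compounds with values here, the one measured step is a 3.3-fold higher number from compound 1 to compound 2 (0.52 log units; beyond the scatter), with acetyl in place of hydrogen on a nitrogen on an aromatic ring.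

Compound 3 (`COc1cccc(-n2nnc(-c3ccccc3NC(=O)Nc3ccc([N+](=O)[O-])cc3)n2)c1`) is changed elsewhere on that part of the molecule: (4-nitrophenyl)amino in place of 4-acetamidophenyl on a carbonyl carbon. In words, (4-nitrophenyl)amino stands in place of 4-acetamidophenyl on a carbonyl carbon. The measured step bears on this change only in part. Within the data shown here, it altered the group that now leaves, and no measured compound carries (4-nitrophenyl)amino.

With only the modest step to compound 2, at 725 nM, as a guide, no step beyond the scatter is expected in this assay, though a slight lean towards a lower number seems reasonable. The estimated change is a 1.5-fold lower number from compound 2 to compound 3 (0.16 log units; within the scatter). Compound 3 is expected at 500 nM, with an estimated range from 130 nM to 1900 nM.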

Compound 3, half-maximal inhibitory concentration: 179 nM
The estimate for compound 3 lay 2.8-fold (0.45 log units) above the measured number, within the range that was stated.
By their numbers in this assay, from the lowest: compounds 3 and 1 (each within the scatter of the next); then compound 2.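

At the carbonyl carbon whose other neighbour is an amide-type nitrogen, the earlier compounds had shown only a change within the 4-aminophenyl group, whereas here the whole group on that carbon is exchanged, and this assay still tolerates it. (4-Nitrophenyl)amino in place of 4-acetamidophenyl gives a 4.1-fold lower number from compound 2 to compound 3 (0.61 log units; beyond the scatter) and so offsets the earlier shift seen with the acetyl group, which was a 3.3-fold higher number from compound 1 to compound 2 (0.52 log units; beyond the scatter) in the opposite direction. Set against 4-aminophenyl, the same (4-nitrophenyl)amino group gives a 1.2-fold lower number from compound 1 to compound 3 (0.08 log units; within the scatter) and cannot be told apart from it, which leaves 4-acetamidophenyl as the only one of the three groups tied to a clearly weaker number.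

The nitro group and the added amino nitrogen arrive together in compound 3, so the compounds shown leave open which of the two matters, a question that a plain phenylamino group, a (4-aminophenyl)amino group or a 4-nitrophenyl group joined directly to the carbonyl carbon would address. Nothing available here offers an explanation for the differences among these three groups.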